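From Fluoro to Ethoxy: Expecting Little Change

A few compounds are considered here, and "the series" means these few. Any claim that something is new, unique, unknown or untested is made for them only; others in the source may bear on it.

Of the compounds shown here, three have been measured in a functional assay on KM12 cells (Homo sapiens) for antiproliferative activity (on this read-out lower numbers stand for stronger inhibition of growth and higher numbers for weaker inhibition of growth), so far, and their numbers sit close together. Compound 1 (`Oc1ccc(-c2nc3ccccc3s2)cc1O`) stands at 15600 nM while compound 2 (`COc1ccc(-c2nc3cc(F)ccc3s2)cc1F`) stands at 20600 nM and compound 3 (`COCOc1ccc(-c2nc3cc(F)ccc3s2)cc1OC`) stands at 19300 nM on the same scale. Compound 2 sits level with the other two: its gap to each lies within the usual scatter of repeated measurements, so the three cannot be ranked.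

The unmeasured compound 4 (`CCOc1cc(-c2nc3cc(F)ccc3s2)ccc1OC`) departs from compound 2 in one place, with ethoxy in place of fluoro on an aromatic carbon, ortho to a methoxy group and meta to a large group (ethoxy in place of fluoro on an aromatic carbon). Within the data shown here, no two measured compounds differ in just one place, so this kind of swap has not been seen on its own. Even so, compound 3 differs from compound 2 in more than one place, and compound 3 still reads 19300 nM on this scale. No step beyond the scatter is therefore expected in this assay, in either direction. The expected move is a 1.1-fold lower number from compound 2 to compound 4 (0.06 log units; within the scatter) and it stays small. Compound 4 is estimated at 18000 nM (range 8000 nM to 40000 nM).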

Compound 4, concentration for 50% growth inhibition: 5420 nM
For compound 4 the middle estimate is 3.3-fold (0.52 log units) above the measured one, outside the stated range (below it).
By their numbers in this assay, from the lowest: compound 4; then compounds 1, 3 and 2 (each within the scatter of the next).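

In this assay, replacing fluoro with ethoxy on this aromatic carbon, ortho to a methoxy group, gives a 3.8-fold lower number from compound 2 to compound 4 (0.58 log units; beyond the scatter), and this single change is large enough to stand out from measurement noise. The earlier compounds shown here sat level with one another and differed in more than one place, so they could not show that any one site matters; this step shows that what sits at this position can change how strongly growth is inhibited. It also shows that a larger group, with 3 heavy atoms in place of 1 and one hydrogen-bond acceptor in place of none, is compatible with stronger inhibition here, but nothing in hand explains why the number falls with this swap.

On these data alone, a single step cannot separate the loss of fluoro from the arrival of the oxygen or from the length of the chain, so it remains open which of these goes with the lower number. Comparing a longer chain such as butoxy, or an amine, on the same carbon would show whether the trend continues or depends on the atom attached to the ring.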